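From ethoxy to isopropylamino: a step of unknown size

The compounds below may be only part of what the source reports. "The series", "measured", "known", "first", "only" and "open" are said of these compounds alone.

Compound 1 `CCOc1nc(N)nc2c1ncn2/C=C1/CC1(CO)CO` stands at > 20000 nM in an ADME assay on CCRF-HSB-2 cells (Homo sapiens) for cytotoxicity, with a stated time of 7 days (a lower number here means that less compound is tolerated, a higher number that more compound is tolerated), which is a limit and not a number. Compound 2 `CCCCCCCCOc1nc(N)nc2c1ncn2/C=C1/CC1(CO)CO` also gives only a limit, > 20000 nM. Compound 3 `CCCSc1nc(N)nc2c1ncn2/C=C1/CC1(CO)CO` gives a true number, 98000 nM. Compound 4 `CC(C)Nc1nc(N)nc2c1ncn2/C=C1/CC1(CO)CO` carries isopropylamino in place of ethoxy on an aromatic carbon. Two measured steps swap the group on that same carbon: a step that the limit leaves unreadable from compound 1 to compound 3, and a step that the limit leaves unreadable from compound 2 to compound 3. Neither has a readable size, and the picture rests largely on (the limit of > 20000 nM in this assay, at which 2 of the 3 values shown sit). Going by the values given here, compound 3, at 98000 nM, is the only firm guide, so compound 4 is expected to be well tolerated in this assay, with no clear direction of change. The expected step is a step that the limit leaves unreadable from compound 1 to compound 4. For compound 4 the estimate is 45000 nM, within an expected range of 12000 nM to 120000 nM.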

Compound 4, half-maximal cytotoxic concentration: > 20000 nM
Compound 4 gave a limit, no number; the forecaster's own chance of this, stated with the estimate: 55%; the middle value lies beyond the limit too.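

Going by these compounds alone, compound 4 gives only a limit, so no step linking it to compound 1, compound 2 or compound 3 can be read. How far these groups on the aromatic carbon separate the compounds in this assay stays open, with most values resting on one limit: the limit of > 20000 nM in this assay, at which 3 of the 4 values shown sit.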